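The compounds below may be only part of what the source reports. "The series", "measured", "known", "first", "only" and "open" are said of these compounds alone.

In an ADME assay on BJ cells (Homo sapiens) for cytotoxicity, with a stated time of 72 h (a lower number here means that less compound is needed, a higher number that more compound is needed for the effect), compound 1 (`CCOC(=O)/C(C)=C/c1cc(/C=C/[C@](C)(/C=C/c2ccc(OC)cc2)CCC=C(C)C)ccc1O`) reads > 36600 nM and this is a limit of the assay, not a number. Compound 2 (`CC(C)=CCC[C@@](C)(/C=C/c1ccc(C)cc1)/C=C/c1ccc(O)cc1`) reads > 36600 nM in this assay and this too is only a limit. Going by the values given here, compound 2 therefore has no number of its own, and the evidence so far amounts to the limit of > 36600 nM in this assay, at which 2 of the 2 values shown sit, with no step between tested compounds to read from it.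

Compound 3 (`CC(C)=CCC[C@](C)(/C=C/c1ccc(O)cc1)/C=C/c1cccc(Cl)c1`) has not yet been measured. It differs from compound 2 in one place: 3-chlorophenyl in place of 4-methylphenyl on a double-bonded chain carbon bound to a double-bonded chain carbon.

Among the compounds with values here, with no measured step as a guide, no change beyond the usual scatter is expected in this assay and compound 3 may well report only a limit. That expectation rests on compound 2 and its reading > 36600 nM which is a limit. Put as an estimate, the step is expected to be an at least 1.0-fold lower number from compound 2 to compound 3 (0.00 log units; that floor lies within the scatter) and no larger than the scatter. For compound 3 the expected value is 36000 nM with an estimated range from 15000 nM to 70000 nM in this reading.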

Compound 3, half-maximal effective concentration: > 36600 nM
Compound 3 ended at the assay's limit (the forecaster's own chance of this, stated with the estimate: 70%); middle value at least 1.0-fold (0.00 log units) from the limit.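

The step from compound 2 to compound 3 in this assay cannot be read, as both readings are limits of the assay and not numbers: the limit of > 36600 nM in this assay, at which 3 of the 3 values shown sit. The compounds shown leave open how far compound 1, compound 2 and compound 3 lie from one another in this assay, and whether any change to the shared core would give a measurable number.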